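The source may hold more compounds than are shown below. What is called first, only, known or untested is meant among the compounds shown, and "the series" means these compounds.

Going by the values given here, in a functional assay on MCF7 cells (Homo sapiens) for cytotoxicity, read by MTT assay, with a stated time of 72 h (a lower number here means a stronger inhibitor, a higher number a weaker inhibitor), compound 2 (`Cc1oc2ncnc(Nc3ccc(OCc4cccc(F)c4)c(Cl)c3)c2c1C(=O)O`) gives 46000 nM, the lower of the two numbers so far, while compound 1 (`CCOC(=O)c1c(C)oc2ncnc(Nc3ccc(OCc4cccc(F)c4)c(Cl)c3)c12`) gives 257000 nM. Compound 3 (`Cc1oc2ncnc(Nc3cccc(Cl)c3)c2c1C(=O)O`) differs from compound 2 by one change, hydrogen in place of (3-fluorobenzyl)oxy on an aromatic carbon. Among the compounds with values here, the only measured step, a 5.6-fold lower number from compound 1 to compound 2 (0.75 log units; beyond the scatter), lies at another place in the molecule, so it offers only a rough guide to size. A modest move towards a higher number is expected, although no measurement tests that direction. The estimated step is a 2.2-fold higher number from compound 2 to compound 3 (0.34 log units; beyond the scatter). For compound 3, the expected value is 100000 nM, within an estimated range of 25000 nM to 400000 nM.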

Compound 3, half-maximal inhibitory concentration: 57500 nM
The estimate for compound 3 lay 1.7-fold (0.24 log units) above the measured number; measured number inside the range.
By their numbers in this assay, from the lowest: compounds 2 and 3 (each within the scatter of the next); then compound 1.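

Replacing (3-fluorobenzyl)oxy, with its whole six-membered aromatic ring, by a single hydrogen gives in this assay only a 1.3-fold higher number from compound 2 to compound 3 (0.10 log units; within the scatter) and so leaves no real difference between the two compounds. On this aromatic carbon, ortho to a chloro group, the large group therefore shows no measurable contribution to the cytotoxicity number, at least alongside the carboxylic acid that both compounds carry. No supporting measurement is available to explain this result.

On these data alone, it remains open whether a small group at this position, such as an amine or a methoxy group, would shift the number. Whether the same swap behaves alike without the carboxylic acid is also unknown.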